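This account rests on a few compounds, and the source may have more. Where it says the series, first, only, none or still open, it means among the compounds named here.

Working notes on the series. In an in vitro functional assay on 1321-N1 cells for agonist activity at Free fatty acid receptor 1 (Homo sapiens), read by fluorescence, spectrophotometry and calcium flux (a lower number here means a smaller maximal response, a higher number a larger maximal response), compound 2 `O=C(O)CCc1ccc(C#Cc2ccnc(Oc3ccccc3)c2)cc1` gives 94%; compound 1 `Cc1ccccc1-c1cc(C#Cc2ccc(CCC(=O)O)cc2)ccn1` gives 92%, and the two sit within the scatter of each other. Within the data shown here, the one measured step, a number 2 percentage points higher from compound 1 to compound 2 (within the scatter), changed the group on the same aromatic carbon without moving the number beyond the scatter. Compound 3 `Cc1cc(C#Cc2ccc(CCC(=O)O)cc2)ccn1` differs from compound 2 by methyl in place of phenoxy on an aromatic carbon. Among the measured compounds shown here, no measured step removes the ring from this position, so the expectation rests only on the unchanged numbers across compounds 1 and 2: the step of a number 9 percentage points lower from compound 2 to compound 3 (within the scatter) is expected to stay modest. Compound 3 is therefore estimated at 85%, with a range of 60% to 100%.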

Compound 3, largest response reached (reported as efficacy), in percent of the reference or control that the assay uses: 102%
The estimate for compound 3 lay 17 percentage points below the measured number; measured number outside the range, above it.
By their numbers in this assay, from the lowest: compounds 1, 2 and 3 (each within the scatter of the next).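

In this assay, methyl in place of phenoxy gives a number 8 percentage points higher from compound 2 to compound 3 (within the scatter), and methyl in place of 2-methylphenyl gives a number 10 percentage points higher from compound 1 to compound 3 (within the scatter). An aromatic ring on this carbon, next to the ring nitrogen, is therefore not needed for the maximal response among these three compounds, since a single methyl serves as well as either larger group. Nothing on hand accounts for this tolerance. Open, from the compounds shown here alone, is whether an amine or a methoxy group on this carbon would keep the response, and how potency runs across the series.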